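A few compounds are considered here, and "the series" means these few. Any claim that something is new, unique, unknown or untested is made for them only; others in the source may bear on it.

Measured so far:
- compound 1 `Oc1ccc(-c2cc(-c3ccc(Cl)cc3)nc(-c3cccs3)c2)cc1`: 0%
- compound 2 `Oc1cccc(-c2cc(-c3ccccc3)nc(-c3ccc(Cl)cc3)c2)c1`: "not determined" (no result reported)

In an assay on isolated protein for inhibition of DNA topoisomerase 1 (Homo sapiens), with a stated time of 30 min, tested at 20 uM (on this read-out lower numbers stand for a weaker effect and higher numbers for a stronger effect at the one concentration tested), compound 1 gives 0%. For compound 2 there is no number in this assay; it stands without a result, so nothing can be said about how it compares with compound 1. Compound 3 `Oc1ccc(-c2cc(-c3ccccc3)nc(-c3ccc(Cl)cc3)c2)cc1` is the next compound, made from compound 2 by one change, (4-hydroxyphenyl in place of 3-hydroxyphenyl on an aromatic carbon). Among the compounds with values here, with no step between measured compounds to go by, the size of this step in this assay is unknown; since compound 1, which also carries a 4-hydroxyphenyl group on the shared core, shows no inhibition, a result for compound 3 within the usual scatter of no effect is the most that can be expected, in neither direction beyond the scatter. Compound 3 is therefore estimated to give about 5%, with a range from 0% to 25%.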

Compound 3, a percentage reported as inhibition, at one concentration (the size of the read-out at that concentration, not a potency): 55.2%
For compound 3 the middle estimate is 50.2 percentage points below the measured one; measured number above the stated range.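

In this assay, putting phenyl in place of thiophen-2-yl gives a number 55.2 percentage points higher from compound 1 to compound 3 (beyond the scatter) and so shows that a compound with a 4-hydroxyphenyl group on the shared core can inhibit the enzyme, and that the group at this one other place can decide whether any inhibition appears. From the compounds shown here alone, the step from compound 2 to compound 3 cannot be read, as compound 2 has no result, so the effect of 4-hydroxyphenyl in place of 3-hydroxyphenyl remains unknown. Nothing available explains why the swap of phenyl for thiophen-2-yl has so large an effect.

Going by these compounds, it remains open whether an amine or a carboxylic acid in place of the hydroxyl group would keep this inhibition. Also open, on these data alone, is how a furan ring or a longer chain would fare where compound 3 carries its phenyl group.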